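Phenyl in Place of Methyl: Expected Inhibition of Compound 4

The source may report more compounds than this note shows. Statements on the series, on what has been measured and on what is new or still open speak of the compounds shown alone.

Measured so far in an assay on isolated protein for inhibition of RAC-alpha serine/threonine-protein kinase (Homo sapiens), read by mobility shift assay, tested at 30 uM; on this read-out higher numbers stand for more inhibition at the one concentration tested (going by the name of the read-out) and lower numbers for less inhibition:
compound 1 `Cc1cc2c(c(N)nn2C)c(=O)[nH]1` gives 11%
compound 2 `Cn1nc(N)c2c(=O)[nH]c(-c3ccccc3)cc21` gives 8%
compound 3 `COCCNc1nc(C)cc2c1c(N)nn2C` gives 6%

All three values lie within the usual scatter of one another, so none can be called stronger or weaker than the others. Between compound 1 and compound 2 the structural change is phenyl in place of methyl on an aromatic carbon, and in this assay this gave a number 3 percentage points lower from compound 1 to compound 2 (within the scatter). Compound 4 `COCCNc1nc(-c2ccccc2)cc2c1c(N)nn2C` carries the same kind of change relative to compound 3: phenyl in place of methyl on an aromatic carbon. The places differ in that in compound 1 the carbon is meta to a group of 1 heavy atom, while in compound 3 it is meta to a (2-methoxyethyl)amino group. How the core of compound 1 and the core of compound 3 differ is not broken down here. Resting on the earlier step of a number 3 percentage points lower from compound 1 to compound 2 (within the scatter), the step from compound 3 to compound 4 is expected to be small, a number 1 percentage points lower from compound 3 to compound 4 (within the scatter). In this assay compound 4 is thus estimated at 5%, expected to fall between -5% and 15%.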

Compound 4, a percentage reported as inhibition, at one concentration (the size of the read-out at that concentration, not a potency): 8%
Compound 4: the middle estimate sits 3 percentage points below what was measured, within the range that was stated.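

In this assay, phenyl in place of methyl on an aromatic carbon gave a number 2 percentage points higher from compound 3 to compound 4 (within the scatter). Set beside the earlier case on a different core, the two steps do not differ: the same change on two cores in this assay, a number 3 percentage points lower (within the scatter) from compound 1 to compound 2 and a number 2 percentage points higher (within the scatter) from compound 3 to compound 4, 5 percentage points apart, within the scatter of two such steps

On these two cores, then, the change shows no sign of depending on the core, and neither step is large enough to stand out from the scatter, but two small steps cannot show that it would behave alike on other cores. The compounds shown leave open what other groups on this aromatic carbon, such as an amine or a carboxylic acid, would do. They also leave open whether a longer chain in place of the (2-methoxyethyl)amino group would give a step beyond the scatter.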